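Swapping an isopropoxy for chloro on the pyridine ring

The source may hold more compounds than are shown below. What is called first, only, known or untested is meant among the compounds shown, and "the series" means these compounds.

Measured compounds:
compound 1 `CN1CC2C=C(c3cncc(Cl)c3)CC(C2)C1`, 1830 nM
compound 2 `C1=C(c2cncc(Oc3ccccc3)c2)CC2CNCC1C2`, 1.9 nM
compound 3 `CC(C)Oc1cncc(C2=CC3CNCC(C2)C3)c1`, 4.8 nM

In an in vitro assay on SH-SY5Y cells for displacement of a labelled ligand from Neuronal acetylcholine receptor; alpha3/beta4 (Homo sapiens) (on this read-out higher numbers stand for weaker inhibition and lower numbers for stronger inhibition), compound 3 gives 4.8 nM, the second highest of the three numbers; compound 2 sits closest and compound 1 farthest. Going by the values given here, the single step measured, a 2.5-fold higher number from compound 2 to compound 3 (0.40 log units; beyond the scatter), swapped one oxygen-bound group for another. Compound 4 `Clc1cncc(C2=CC3CNCC(C2)C3)c1` is reached from compound 3 by chloro in place of isopropoxy on an aromatic carbon. Among the compounds with values here, no measured step covers this swap. Compound 1 also carries a chloro, but it differs from compound 4 in two places, so the number of compound 1, 1830 nM, is only a loose guide. The number for compound 4 is therefore expected to rise by a modest to sizeable amount, a 4.2-fold higher number from compound 3 to compound 4 (0.62 log units; beyond the scatter). Compound 4 is estimated at 20 nM, in a range from 3 nM to 150 nM.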

Compound 4, inhibition constant: 40 nM
Beside the measured number, compound 4's estimate is 2.0-fold (0.30 log units) below it, within the range that was stated.
By their numbers in this assay, from the lowest: compound 2; then compound 3; then compound 4; then compound 1.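

In this assay, chloro on this aromatic carbon binds less well than either oxygen-bound group: isopropoxy gives way to chloro with an 8.3-fold higher number from compound 3 to compound 4 (0.92 log units; beyond the scatter) and phenoxy with a 21-fold higher number from compound 2 to compound 4 (1.32 log units; beyond the scatter). With chloro held fixed, the amine nitrogen in the ring also matters, as hydrogen in place of methyl gives a 46-fold lower number from compound 1 to compound 4 (1.66 log units; beyond the scatter). The data shown offer no measured reason for these steps.

From the compounds shown here alone, whether an amine or a longer chain such as butoxy on this aromatic carbon would fall nearer chloro or nearer the oxygen-bound groups remains open. So does whether methyl on the nitrogen would cost as much with isopropoxy or phenoxy on the ring.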